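This account rests on a few compounds, and the source may have more. Where it says the series, first, only, none or still open, it means among the compounds named here.

Measured compounds in a functional assay on SW480 cells (Homo sapiens) for cytotoxicity, read by MTT assay, with a stated time of 24 h; a lower number here means a stronger inhibitor, a higher number a weaker inhibitor:

- compound 1, `C=CC1=C(C(=O)NCc2ccccc2)C(c2ccc(OC)cc2)OC1` — 39500 nM
- compound 2, `C=CC1=C(C(=O)NCCCCC)C(c2ccc(Cl)c(Cl)c2)OC1` — 27500 nM
- compound 3, `C=CC1=C(C(=O)NCc2ccc(OC)c(OC)c2)C(c2ccc(F)cc2)OC1` — value is a limit, > 100000 nM

Compound 2 holds one of the two numbers recorded in this assay; compound 1 sits close to it, and the gap between them stays within the scatter, so neither can be set above the other. For compound 3 this assay returns only a limit, > 100000 nM, not a number; this is the point at which (the limit of > 100000 nM in this assay, at which 1 of the 3 values shown sits), and nothing more can be read from it.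

The step under study goes from compound 2 to compound 4, `C=CC1=C(C(=O)O)C(c2ccc(Cl)c(Cl)c2)OC1`, which is not yet measured. The change is hydroxy in place of pentylamino on a carbonyl carbon, in words: hydroxy in place of pentylamino on a carbonyl carbon. No measured pair in the set shares this change, so its size cannot be taken from any step shown; the three compounds differ in several places at once.

The expectation for compound 4 is a move toward a higher number in this assay, with a real chance that only a limit is returned: compound 4 is estimated at 80000 nM, within 30000 nM to 200000 nM. That estimate implies a step of a 2.9-fold higher number from compound 2 to compound 4 (0.46 log units; beyond the scatter), beyond the scatter.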

Compound 4, half-maximal inhibitory concentration: > 100000 nM
Compound 4: only a limit was reported; the forecaster's own chance of this, stated with the estimate: 45%; at least 1.2-fold (0.09 log units) between middle value and limit.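

Notes on the carbonyl position: this is the only pair in the set that differs in one place, so the effect of this position can be read apart from the rest of the core, and hydroxy in place of pentylamino on the carbonyl carbon gives an at least 3.6-fold higher number from compound 2 to compound 4 (0.56 log units; beyond the scatter) in this assay. As far as these compounds go, compound 4 returns only a limit, > 100000 nM, so the step is bounded on one side and its full size stays unknown: the limit of > 100000 nM in this assay, at which 2 of the 4 values shown sit. With the rest of compound 2 unchanged, the measurable number in this assay therefore depends on what stands on the carbonyl carbon, which compounds 1 and 3 could not show, as each differs from compound 2 in several places at once.

Still open, from the compounds shown here alone, is whether the number held by compound 2 rests on the amide nitrogen or on the pentyl chain, and a primary amide, a methyl ester or a propylamino chain on the same carbonyl carbon would separate the two. Also open, going by these compounds, is whether a hexylamino or longer chain at this position moves the number in either direction, or leaves it within the scatter of compound 2.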